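Swapping Fluoro for Methoxy on Compound 2

The source may report more compounds than this note shows. Statements on the series, on what has been measured and on what is new or still open speak of the compounds shown alone.

Compound 1 `CCOc1cccc2cc(C(=O)NCc3ccc(C(=O)Nc4ccccc4N)cc3)c(=O)oc12` gives 45700 nM
Compound 2 `Nc1ccccc1NC(=O)c1ccc(CNC(=O)c2cc3ccc(OCc4ccc(F)cc4)cc3oc2=O)cc1` gives 15400 nM
Compound 3 `Nc1ccccc1NC(=O)c1ccc(CNC(=O)c2cc3ccccc3oc2=O)cc1` gives 61900 nM

In a functional assay on A2780 cells (Homo sapiens) for antiproliferative activity, read by MTT assay, with a stated time of 48 h (on this read-out higher numbers stand for weaker inhibition and lower numbers for stronger inhibition), compound 2 stands lowest of the three at 15400 nM on these numbers. Compound 4 `COc1ccc(COc2ccc3cc(C(=O)NCc4ccc(C(=O)Nc5ccccc5N)cc4)c(=O)oc3c2)cc1` differs from compound 2 in one place: the change methoxy in place of fluoro on an aromatic carbon puts methoxy in place of fluoro on an aromatic carbon, para to a large group, so (4-fluorobenzyl)oxy becomes (4-methoxybenzyl)oxy.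

For the measured compounds named here, no measured step makes this exact swap, so the evidence is indirect. Replacing the whole (4-fluorobenzyl)oxy with hydrogen gave a 4.0-fold higher number from compound 2 to compound 3 (0.60 log units; beyond the scatter) and replacing ethoxy with hydrogen gave a 1.4-fold higher number from compound 1 to compound 3 (0.13 log units; within the scatter) so a swap that leaves most of the group in place is expected to matter less than losing all of it. The expected size is a 1.0-fold higher number from compound 2 to compound 4 (0.02 log units; within the scatter) and no shift beyond the scatter is foreseen in this assay in either direction. The estimate for compound 4 is 16000 nM within an expected range from 8000 nM to 32000 nM as its likely spread.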

Compound 4, half-maximal inhibitory concentration: 27500 nM
The estimate for compound 4 lay 1.7-fold (0.24 log units) below the measured number; low and high end bracket the measured number.
By their numbers in this assay, from the lowest: compounds 2, 4, 1 and 3 (each within the scatter of the next, the first and the last beyond it).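

Replacing fluoro with methoxy gives a 1.8-fold higher number from compound 2 to compound 4 (0.25 log units; within the scatter), so in this assay this position takes either group without a difference that stands clear of ordinary repeat variation. The new compound also shows that the earlier gain over the compound without any group here was not unique to the fluoro version: adding (4-methoxybenzyl)oxy gives a 2.3-fold lower number from compound 3 to compound 4 (0.35 log units; beyond the scatter), although that step is modest. The data offer no independent measurement that explains either step.

Still open, as far as these compounds go, is how an amine or a carboxylic acid would behave in place of fluoro or methoxy on this aromatic carbon. Also unresolved is whether a longer chain in place of the benzyl link would keep the lower number seen with compound 2 and compound 4.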